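Replacing the nitro group of compound 3 with amino

The source may hold more compounds than are shown below. What is called first, only, known or untested is meant among the compounds shown, and "the series" means these compounds.

Values so far in an ADME assay on L929 cells (Mus musculus) for cytotoxicity, read by resazurin assay, with a stated time of 72 h; a higher number here means a weaker inhibitor, a lower number a stronger inhibitor:
Compound 1 `O=C(/C=C/c1ccc2c(c1)B(O)OC2)c1ccc([N+](=O)[O-])cc1` reads > 10 ug/mL as a limit
Compound 2 `COc1ccccc1C(=O)/C=C/c1ccc2c(c1)B(O)OC2` reads 6.35 ug/mL as a number
Compound 3 `COc1cc(C(=O)/C=C/c2ccc3c(c2)B(O)OC3)ccc1[N+](=O)[O-]` reads > 10 ug/mL as a limit

Compound 3 stands at > 10 ug/mL as a limit of the assay, not a number. This is the limit of > 10 ug/mL in this assay, at which 2 of the 3 values shown sit, a place it shares with compound 1.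

Compound 4 `COc1cc(C(=O)/C=C/c2ccc3c(c2)B(O)OC3)ccc1N` has amino in place of nitro on an aromatic carbon, in detail (amino in place of nitro on an aromatic carbon), and the rest of the structure is unchanged.

Among the measured compounds shown here, the one measured step nearby is a step that the two limits leave unreadable from compound 1 to compound 3 and it concerns the methoxy group with the nitro kept, so it offers no size to carry over. Both compounds at the limit carry nitro. For the measured compounds named here, compound 2, which has no nitro, gives 6.35 ug/mL as the only number among the three. Going by the values given here, on this single contrast, a lower number is expected for compound 4 in this assay, although no measured step fixes the size. The expected step is an at least 1.4-fold lower number from compound 3 to compound 4 (0.15 log units; that floor lies within the scatter) toward a stronger inhibitor, and its size is only loosely estimated. For compound 4 the estimated value is 7 ug/mL with an expected range from 2.5 ug/mL to 12 ug/mL and a real chance of only a limit.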

Compound 4, half-maximal inhibitory concentration: 1.45 ug/mL
Estimate against measurement, compound 4: 4.8-fold (0.68 log units) above; measured number below the stated range.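

In this assay, among the compounds shown here, amino in place of nitro on an aromatic carbon, ortho to a methoxy group and para to a large group, gives the first readable step: an at least 6.8-fold lower number from compound 3 to compound 4 (0.83 log units; beyond the scatter). For the compounds shown here, the only earlier step between compounds differing in one place, which concerned the methoxy group with the nitro kept, cannot be read, so this change is the first to show that a single replacement on this ring can move the read-out by more than the usual scatter. Compound 3 reads > 10 ug/mL, which is a limit and not a number, so the step gives only a floor for the change, and the full size remains unknown: the limit of > 10 ug/mL in this assay, at which 2 of the 4 values shown sit.

On these data alone, it remains open whether the shift follows from the presence of amino or simply from the absence of nitro, and whether a hydroxy group, a dimethylamino group or an acetamide on the same carbon would read like compound 4. It is also open how much the methoxy group contributes once amino is in place, since the compounds shown offer no amino partner carrying hydrogen there instead.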